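Bromo in place of hydrogen on a benzyl-substituted core

This account rests on a few compounds, and the source may have more. Where it says the series, first, only, none or still open, it means among the compounds named here.

Measured compounds:
- compound 1, `O=c1nc2ccc(Br)cn2cc1Cc1ccccc1`: > 1000000 nM
- compound 2, `O=C1N=C2C=CC=CN2CC1C(O)c1cccs1`: 248000 nM
- compound 3, `Nc1cc(Br)cn2cc(Cc3ccccc3)c(=O)nc12`: > 1000000 nM

In a functional assay on A549 cells (Homo sapiens) for cytotoxicity, read by MTT assay, with a stated time of 24 h (on this read-out higher numbers stand for weaker inhibition and lower numbers for stronger inhibition), compound 1 reaches only a limit of the assay, > 1000000 nM. Compound 3, `Nc1cc(Br)cn2cc(Cc3ccccc3)c(=O)nc12`, likewise sits at a limit, > 1000000 nM. Among the measured compounds shown here, the one single-point step, a step that the two limits leave unreadable from compound 1 to compound 3, is therefore not readable in size. For the measured compounds named here, compound 2, `O=C1N=C2C=CC=CN2CC1C(O)c1cccs1`, is the only one with a number, 248000 nM, but it differs from compound 1 in more than one place, so its value shows nothing about any single change. Where compound 1 stands is thus known only as a limit, and it shares that with the limit of > 1000000 nM in this assay, at which 2 of the 3 values shown sit.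

Compound 4, `O=c1nc2ccc(Br)cn2cc1Cc1ccc(Br)cc1`, differs from compound 1 by bromo in place of hydrogen on an aromatic carbon. Going by the values given here, no measured step bears on bromo entering at this position, and the only step from compound 1 is unreadable. No direction beyond the scatter can be inferred for this change in this assay. Compound 4 is therefore expected to remain at or near the limit where compound 1 sits, with an estimate of 1000000 nM and a range from 300000 nM to 3000000 nM. The step this estimate implies, a number no higher from compound 1 to compound 4 (the limit leaves the size open), is expected to be none beyond the scatter.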

Compound 4, half-maximal inhibitory concentration: 102000 nM
For compound 4 the middle estimate is 9.8-fold (0.99 log units) above the measured one, and the stated range ends above it.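

Among the compounds shown here, a bromo entering on a six-membered aromatic ring of carbon only, para to a large group, brings an at least 9.8-fold lower number from compound 1 to compound 4 (0.99 log units; beyond the scatter) in this assay, and this is the first single change whose effect can be read. The earlier step, amino in place of hydrogen, cannot be read, so until compound 4 nothing showed that a one-atom change could bring the number down from the limit at all. As far as these compounds go, compound 1 stands at a limit, so the step to compound 4 gives only a lower bound on the size of this change, and the true size stays open: the limit of > 1000000 nM in this assay, at which 2 of the 4 values shown sit.

The compounds shown leave open whether chloro, methoxy or an amine on the same aromatic carbon would lower the number as bromo does, or whether a carboxylic acid there would leave it at the limit. They also leave open whether bromo at this carbon would give a readable step on the core of compound 3, which carries the amino group, and whether the change depends on the bromo already present on the shared core.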